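The source may hold more compounds than are shown below. What is called first, only, known or untested is meant among the compounds shown, and "the series" means these compounds.

In a functional assay on MCF7 cells (Homo sapiens) for antiproliferative activity, read by MTT assay, with stated times of 24 h and 72 h (a higher number here means a weaker inhibitor, a lower number a stronger inhibitor), compound 1 `COc1cc(N2C(=O)[C@@H](Oc3ccccc3)[C@H]2c2ccc(Br)cc2)cc(OC)c1OC` gives 48000 nM and compound 2 `COc1cc(N2C(=O)[C@@H](Oc3ccccc3)[C@H]2c2ccc(N(C)C)cc2)cc(OC)c1OC` gives 31000 nM while compound 3 `COc1cc(N2C(=O)[C@@H](Oc3ccccc3)[C@H]2c2ccc(S(C)(=O)=O)cc2)cc(OC)c1OC` gives 62000 nM. Compound 3 does not separate from the other two: a 1.3-fold higher number from compound 1 to compound 3 (0.11 log units; within the scatter) and a 2.0-fold higher number from compound 2 to compound 3 (0.30 log units; within the scatter) both stay within the scatter. The compound still to be measured, compound 4 `COc1cc(N2C(=O)[C@@H](Oc3ccccc3)[C@H]2c2ccc(O)cc2)cc(OC)c1OC`, keeps the shared core and carries hydroxy in place of methylsulfonyl on an aromatic carbon, para to a large group: hydroxy in place of methylsulfonyl on an aromatic carbon. Within the data shown here, no measured step makes this exact change, but all three steps at hand concern the same place. Besides the two above, a 1.5-fold lower number from compound 1 to compound 2 (0.19 log units; within the scatter) also stays within the scatter, so exchanging bromo, dimethylamino and methylsulfonyl there has not moved the number beyond the scatter. This is a thin base, and none of the three compounds carries hydroxy. No step beyond the scatter is therefore expected in this assay, and the data favour no direction. The estimated step is a 1.4-fold lower number from compound 3 to compound 4 (0.14 log units; within the scatter). For compound 4 the expected value is 45000 nM, with an estimated range from 14000 nM to 100000 nM.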

Compound 4, half-maximal inhibitory concentration: 48000 nM
Compound 4: the middle estimate sits 1.1-fold (0.03 log units) below what was measured; measured number inside the range.
By their numbers in this assay, from the lowest: compounds 2, 1, 4 and 3 (each within the scatter of the next).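

Hydroxy now joins bromo, dimethylamino and methylsulfonyl at this place on the aromatic ring in this assay, and none of its three steps leaves the scatter (from methylsulfonyl a 1.3-fold lower number from compound 3 to compound 4 (0.11 log units; within the scatter); from dimethylamino a 1.5-fold higher number from compound 2 to compound 4 (0.19 log units; within the scatter); from bromo no change at the digits printed from compound 1 to compound 4 (within the scatter)). Exchanging methylsulfonyl, with four heavy atoms and no hydrogen-bond donor, for hydroxy, with one heavy atom and one hydrogen-bond donor, therefore leaves the number within the scatter in this set. No supporting measurement is available to explain this lack of separation.

On these data alone, whether a carboxylic acid, a primary amine or a longer alkoxy chain at this place would give a step beyond the scatter remains open. As far as these compounds go, all four compounds share the same core, so the effect of changes elsewhere in the molecule also remains open.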